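Adding a Second Chlorine: From Compound 3 to Compound 4

A few compounds are considered here, and "the series" means these few. Any claim that something is new, unique, unknown or untested is made for them only; others in the source may bear on it.

Three measured compounds share one core and differ only in where a single chlorine sits on the ring attached to the carbonyl. Compound 1 `O=C(/C=C/C1=Cc2ccccc2OC1)c1ccccc1Cl` gives 52.3% in a functional assay on the whole organism for inhibition, with Mus musculus as the target, with a stated time of 1 h, at a dose of 30 mg/kg by the intraperitoneal route; a lower number here means less inhibition, a higher number more inhibition at the dose given (going by the name of the read-out). Compound 2 `O=C(/C=C/C1=Cc2ccccc2OC1)c1cccc(Cl)c1` gives 51% in this assay. Compound 3 `O=C(/C=C/C1=Cc2ccccc2OC1)c1ccc(Cl)cc1` gives 56.1% in this assay. Compound 3 has the highest of the three numbers, but the steps toward it are small: a number 3.8 percentage points higher from compound 1 to compound 3 (within the scatter) and a number 5.1 percentage points higher from compound 2 to compound 3 (within the scatter), and also a number 1.3 percentage points lower from compound 1 to compound 2 (within the scatter), all within the scatter, so the three numbers are level. Compound 4 `O=C(/C=C/C1=Cc2ccccc2OC1)c1ccc(Cl)cc1Cl` keeps the 4-chlorophenyl of compound 3 and carries one more change: chloro in place of hydrogen on an aromatic carbon. No measured step adds a second chlorine; the steps shown only move a single chlorine around the ring, and each stayed within the scatter. A small step is therefore expected for compound 4, namely a number 0.1 percentage points lower from compound 3 to compound 4 (within the scatter) in this assay. Compound 4 is estimated at 56%, with a range from 42% to 70%.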

Compound 4, a percentage reported as inhibition, in the whole organism at one dose (the size of the read-out at that dose, not a potency): 53.3%
Beside the measured number, compound 4's estimate is 2.7 percentage points above it, within the range that was stated.
By their numbers in this assay, from the lowest: compounds 2, 1, 4 and 3 (each within the scatter of the next).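

Compound 4 is the first shown with two chlorines on the ring attached to the carbonyl, and a single addition links it to two of the earlier compounds. With the new chloro ortho to a large group and meta to a chloro group, this assay gives a number 2.8 percentage points lower from compound 3 to compound 4 (within the scatter) and, from the other single-chlorine compound, a number 1 percentage points higher from compound 1 to compound 4 (within the scatter), so in these two pairs a second chlorine leaves the number level, just as moving one chlorine did. No available evidence bears on the reason for this.

As far as these compounds go, whether this level result holds only for chlorine stays open, since an amine or a carboxylic acid at the same ring carbon could behave differently. A longer chain there is equally unexplored among the compounds shown.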